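A few compounds are considered here, and "the series" means these few. Any claim that something is new, unique, unknown or untested is made for them only; others in the source may bear on it.

Compound 1 `COc1ccc(/C=N/NC(=O)c2cccnc2Nc2cccc(C(F)(F)F)c2)cc1` holds the higher of the two numbers measured in a functional assay on the whole organism (Abdomen, strain NMRI) for inhibition, with Mus musculus as the target, in the writhing test, with a stated time of 30 min, at a dose of 10 mg/kg (on this read-out higher numbers stand for more inhibition at the one dose given (going by the name of the read-out) and lower numbers for less inhibition), giving 97.4%. Compound 2 `O=C(N/N=C/c1cccnc1)c1cccnc1Nc1cccc(C(F)(F)F)c1`, which carries pyridin-3-yl in place of 4-methoxyphenyl, gives 51.4%, and that step is a number 46 percentage points lower from compound 1 to compound 2 (beyond the scatter). Compound 3 `O=C(N/N=C/c1ccncc1)c1cccnc1Nc1cccc(C(F)(F)F)c1` differs from compound 1 by pyridin-4-yl in place of 4-methoxyphenyl on a carbon with a double bond to nitrogen. For the measured compounds named here, the one measured step bears directly on this change, since it also swaps 4-methoxyphenyl for a pyridinyl ring at the same place, so a large downward step is expected, roughly a number 47.4 percentage points lower from compound 1 to compound 3 (beyond the scatter). Compound 3 is therefore estimated at 50%, expected to fall between 25% and 80%.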

Compound 3, a percentage reported as inhibition, in the whole organism at one dose (the size of the read-out at that dose, not a potency): 85.6%
For compound 3 the middle estimate is 35.6 percentage points below the measured one; the whole stated range lies below it.
By their numbers in this assay, from the lowest: compound 2; then compound 3; then compound 1.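

At this place on the carbon with a double bond to nitrogen, a pyridinyl ring need not lose most of the effect, since pyridin-4-yl in place of 4-methoxyphenyl gives a number 11.8 percentage points lower from compound 1 to compound 3 (beyond the scatter). The two pyridinyl groups themselves differ widely, with pyridin-4-yl in place of pyridin-3-yl giving a number 34.2 percentage points higher from compound 2 to compound 3 (beyond the scatter). Nothing available here explains that difference. Still open, on these data alone, is how pyridin-2-yl would behave at this place, and whether unsubstituted phenyl or a phenyl ring carrying a carboxylic acid would keep the effect.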